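Adding a Second Methoxy Group: What the Numbers Suggest

This account rests on a few compounds, and the source may have more. Where it says the series, first, only, none or still open, it means among the compounds named here.

Compound 1 `O=C1N=C(N2N=C(c3ccccc3)CC2c2ccccc2O)S/C1=C1/C(=O)Nc2ccc(Br)cc21` and compound 2 `COc1ccc(C2CC(c3ccccc3)=NN2C2=NC(=O)/C(=C3\C(=O)Nc4ccc(Br)cc43)S2)cc1` share one core and differ in a single place: 4-methoxyphenyl in place of 2-hydroxyphenyl on a saturated ring carbon. In a functional assay on cells (Leukemia cell, Homo sapiens) for cytotoxicity, read by sulforhodamine B assay, with a stated time of 48 h (on this read-out lower numbers stand for stronger inhibition of growth and higher numbers for weaker inhibition of growth), compound 1 gives 270 nM and compound 2 gives 250 nM, and the step of a 1.1-fold lower number from compound 1 to compound 2 (0.03 log units; within the scatter) leaves the two level, so compound 2 stands beside compound 1 rather than apart from it. Compound 3 `COc1ccc(C2=NN(C3=NC(=O)/C(=C4\C(=O)Nc5ccc(Br)cc54)S3)C(c3ccc(OC)cc3)C2)cc1` carries methoxy in place of hydrogen on an aromatic carbon. For the measured compounds named here, no measured step touches that ring, and the one step that was measured was small. Compound 3 is therefore expected to give 250 nM, somewhere between 120 nM and 520 nM. The expected step is no change at the digits printed from compound 2 to compound 3 (within the scatter), nothing beyond the scatter.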

Compound 3, concentration for 50% growth inhibition: 280 nM
Compound 3: the middle estimate sits 1.1-fold (0.05 log units) below what was measured, within the range that was stated.
By their numbers in this assay, from the lowest: compounds 2, 1 and 3 (each within the scatter of the next).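

For the compounds shown here, the earlier pair changed a different ring, so this is the first step to touch the phenyl, which becomes 4-methoxyphenyl. In this assay, methoxy in place of hydrogen on this aromatic carbon, para to a large group, gives a 1.1-fold higher number from compound 2 to compound 3 (0.05 log units; within the scatter), so at this position the added methoxy leaves the reading level. No measurement shown offers an explanation for this result. Going by these compounds, whether an amine, a carboxylic acid or a longer chain at this position would also leave the number level remains open. So does the effect of methoxy on another carbon of this ring.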